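One Step from Compound 2: Urea Becomes Amide

This account rests on a few compounds, and the source may have more. Where it says the series, first, only, none or still open, it means among the compounds named here.

For the measured compounds named here, in a functional assay on PC-3 cells (Homo sapiens) for inhibition, read by sulforhodamine B assay, with a stated time of 48 h, tested at 100 uM (a lower number here means a stronger effect, a higher number a weaker effect of the compound at the concentration tested), compound 2 `COc1cc(Cl)cc(-c2nn(-c3cccc(NC(=O)Nc4ccc(Cl)c(C(F)(F)F)c4)c3)cc2-c2ccncc2)c1` gives -15%, the highest of the three numbers so far. Compound 3 `COc1cc(Cl)cc(-c2nn(-c3cccc(NC(=O)Nc4cc(C(F)(F)F)cc(C(F)(F)F)c4)c3)cc2-c2ccncc2)c1` gives -44% and compound 1 `O=C(Nc1cccc(-n2cc(-c3ccncc3)c(-c3cc(O)cc(Cl)c3)n2)c1)Nc1ccc(Cl)c(C(F)(F)F)c1` gives -83%, both beyond the scatter below compound 2. Going by the values given here, the only measured step, a number 68 percentage points higher from compound 1 to compound 2 (beyond the scatter), concerns a methyl in place of hydrogen on an oxygen on an aromatic ring and does not touch the part altered here. Compound 4 `COc1cc(Cl)cc(-c2nn(-c3cccc(NC(=O)c4cccc(C(F)(F)F)c4)c3)cc2-c2ccncc2)c1` differs from compound 2 by 3-(trifluoromethyl)phenyl in place of (4-chloro-3-(trifluoromethyl)phenyl)amino on a carbonyl carbon. Among the compounds with values here, no measured step bears on this change, so its size and direction remain open, and a wide range is appropriate. The estimate for compound 4 is -30%, ranging from -90% to 15%, which means an expected step of a number 15 percentage points lower from compound 2 to compound 4 (beyond the scatter).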

Compound 4, a percentage reported as activity, at one concentration (the size of the read-out at that concentration, not a potency): 17%
The estimate for compound 4 lay 47 percentage points below the measured number, outside the stated range (above it).
By their numbers in this assay, from the lowest: compound 1; then compound 3; then compound 2; then compound 4.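

Swapping (4-chloro-3-(trifluoromethyl)phenyl)amino for 3-(trifluoromethyl)phenyl on the carbonyl carbon gives a number 32 percentage points higher from compound 2 to compound 4 (beyond the scatter) in this assay, so the effect weakens. For the compounds shown here, this is the first sign that the group on this carbonyl carbon matters, and that turning the urea into an amide does not preserve the effect. Nothing available explains the shift. Going by these compounds alone, the single step removes both the amide hydrogen and the chlorine, so their shares cannot be separated. From the compounds shown here alone, how a piperidine or a short alkyl chain on this carbonyl carbon would behave also remains open.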